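This account rests on a few compounds, and the source may have more. Where it says the series, first, only, none or still open, it means among the compounds named here.

In a functional assay (mast cells) for inhibition, with Rattus norvegicus as the target (on this read-out higher numbers stand for an effect only at larger amounts of compound and lower numbers for an effect already at smaller amounts), compound 1 (`CC1C/C(=N\Nc2ccccc2)c2ncc(C(=O)O)c(=O)n2C1`) gives 13000 nM and compound 2 (`CC1CC/C(=N\Nc2cccc(Cl)c2)c2ncc(C(=O)O)c(=O)n21`) gives 311000 nM as its reading. Compound 2 thus has the higher of the two numbers, beyond the usual scatter, so it takes effect only at larger amounts than compound 1. Compound 3 (`CC1CC/C(=N\Nc2ccccc2O)c2ncc(C(=O)O)c(=O)n21`) has not yet been measured. It carries 2-hydroxyphenyl in place of 3-chlorophenyl on an amine nitrogen. Among the compounds with values here, no measured pair shows a change of this kind, so the data give no direct guide to its size. Compound 1 at 13000 nM is the only other reference point, so a move toward a lower number is expected, though with wide uncertainty. The expected change is a 7.8-fold lower number from compound 2 to compound 3 (0.89 log units; beyond the scatter) in this reading. For compound 3 the estimate is 40000 nM with an expected range from 5000 nM to 300000 nM in this assay once it is tested.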

Compound 3, half-maximal effective concentration: 208000 nM
Estimate against measurement, compound 3: 5.2-fold (0.72 log units) below; low and high end bracket the measured number.
By their numbers in this assay, from the lowest: compound 1; then compounds 3 and 2 (each within the scatter of the next).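

In this assay, placing 2-hydroxyphenyl where compound 2 has 3-chlorophenyl on the amine nitrogen gives a 1.5-fold lower number from compound 2 to compound 3 (0.17 log units; within the scatter) and stays within the usual scatter of repeated measurements. This position therefore tolerates an exchange of chlorine for a hydroxyl oxygen, with one hydrogen-bond donor and one hydrogen-bond acceptor entering, without a measurable shift in this read-out. No supporting data are available to account for this result.

This single pair changes both the substituent and its place on the phenyl ring, so 3-hydroxyphenyl and 2-chlorophenyl would be needed to separate those two changes. Also open, as far as these compounds go, is how an unsubstituted phenyl, a methoxyphenyl or a carboxyphenyl would read on the core of compound 2, which differs from the core of compound 1.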